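The source may report more compounds than this note shows. Statements on the series, on what has been measured and on what is new or still open speak of the compounds shown alone.

Measured in a physicochemical assay, with a stated time of 6 min; on this read-out higher numbers stand for weaker inhibition and lower numbers for stronger inhibition:
Compound 1 `Cc1ccc(NC(=O)Nc2nc(-c3cc4cc(Br)ccc4o3)cs2)cc1`: > 200000 nM (a limit)
Compound 2 `O=C(Nc1ccc([N+](=O)[O-])cc1)Nc1nc(-c2cc3cc(Br)ccc3o2)cs1`: > 200000 nM (a limit)
Compound 3 `O=C(Nc1ccc([N+](=O)[O-])cc1)Nc1nc(-c2cc3ccccc3o2)cs1`: 19300 nM

Compound 2 has no exact number and stands at the limit of > 200000 nM in this assay, at which 2 of the 3 values shown sit. Compound 1 also gives only a limit, so nitro in place of methyl on an aromatic carbon is a step that the two limits leave unreadable from compound 1 to compound 2. Going by the values given here, the one readable step is hydrogen in place of bromo on an aromatic carbon, which gives an at least 10-fold lower number from compound 2 to compound 3 (1.01 log units; beyond the scatter).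

Compound 4 `O=C(Nc1cccc([N+](=O)[O-])c1)Nc1nc(-c2cc3cc(Br)ccc3o2)cs1` keeps the bromo and differs in one place: 3-nitrophenyl in place of 4-nitrophenyl on an amide-type nitrogen. In words, this is 3-nitrophenyl in place of 4-nitrophenyl on an amide-type nitrogen. Neither measured step moves the nitro group, so both are only loose guides. Both measured compounds that carry the bromo sit at the limit, while compound 3, which lacks it, gives a number. A step beyond the scatter is therefore not expected in this assay, and compound 4 may well return only a limit too. Any number that does appear is expected near the top of the measurable range. Compound 4 is estimated at 150000 nM, with an expected range from 40000 nM to 400000 nM. The estimate amounts to an expected at least 1.3-fold lower number from compound 2 to compound 4 (0.12 log units; that floor lies within the scatter).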

Compound 4, half-maximal inhibitory concentration: 159000 nM
Compound 4: the middle estimate sits 1.1-fold (0.03 log units) below what was measured; the range from low to high includes it.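

With 3-nitrophenyl in place of 4-nitrophenyl on an amide-type nitrogen, compound 4 is the only one of the three bromo compounds shown that gives a number in this assay: compound 4 gives 159000 nM. The change at this nitrogen reads as an at least 1.2-fold lower number from compound 2 to compound 4 (0.09 log units; that floor lies within the scatter), and 3-nitrophenyl in place of 4-methylphenyl at the same nitrogen reads as an at least 1.2-fold lower number from compound 1 to compound 4 (0.09 log units; that floor lies within the scatter). Both steps are only floors, so the new result shows that a number can be read at this position with the bromo kept, but not that the change moves the value beyond the scatter, because compound 1 and compound 2 each give only a limit: the limit of > 200000 nM in this assay, at which 2 of the 4 values shown sit.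

As far as these compounds go, the true size of both steps stays open, as does whether removing the bromo from compound 4 would give a step like an at least 10-fold lower number from compound 2 to compound 3 (1.01 log units; beyond the scatter). The compounds shown also leave open how an amine or a carboxylic acid on the phenyl ring at this nitrogen would read in this assay.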